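Replacing the Methoxy Group on a Double-Bonded Nitrogen

A few compounds are considered here, and "the series" means these few. Any claim that something is new, unique, unknown or untested is made for them only; others in the source may bear on it.

In an ADME assay on Vero cells (Chlorocebus sabaeus) for cytotoxicity, read by MTT assay, with a stated time of 72 h (a higher number here means that more compound is tolerated, a lower number that less compound is tolerated), compound 1 `COc1c(N2C[C@H]3CCCN(C(=O)Cn4cc(CN5C(=O)/C(=N/O)c6ccccc65)nn4)[C@H]3C2)c(F)cc2c(=O)c(C(=O)O)cn(C3CC3)c12` gives 32 ug/mL, compound 2 `CO/N=C1/C(=O)N(Cc2cn(CC(=O)N3CCC[C@@H]4CN(c5c(F)cc6c(=O)c(C(=O)O)cn(C7CC7)c6c5OC)C[C@@H]43)nn2)c2ccccc21` gives 128 ug/mL, and compound 3 `CO/N=C1/C(=O)N(Cc2cn(CC(=O)N3CCC[C@@H]4CN(c5c(F)cc6c(=O)c(C(=O)O)cn(C7CC7)c6c5OC)C[C@@H]43)nn2)c2ccc(C)cc21` gives 64 ug/mL. Compound 2 shares the upper end of these three numbers with compound 3, the step being a 2.0-fold lower number from compound 2 to compound 3 (0.30 log units; within the scatter). That step lies away from the group that changes next, so it says little here.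

Compound 4 `COc1c(N2C[C@H]3CCCN(C(=O)Cn4cc(CN5C(=O)/C(=N/NC(N)=S)c6ccccc65)nn4)[C@H]3C2)c(F)cc2c(=O)c(C(=O)O)cn(C3CC3)c12` keeps the rest of compound 2 but swaps the methoxy on the double-bonded nitrogen for a larger group: a group of 4 heavy atoms (1 carbon, 2 nitrogen, 1 sulfur; no ring) in place of a group of 2 heavy atoms (1 carbon, 1 oxygen; no ring), on a double-bonded nitrogen. The closest evidence is the modest step of a 4.0-fold higher number from compound 1 to compound 2 (0.60 log units; beyond the scatter), which concerns the same site. Within the data shown here, compound 4, like compound 1, has no methoxy there, although no measured compound carries the entering group, so any expectation remains loose. An estimated step of a 4.0-fold lower number from compound 2 to compound 4 (0.60 log units; beyond the scatter) is therefore expected in this assay, similar in size to that earlier step. For compound 4 the expected value is 32 ug/mL, with an estimated range of 12 ug/mL to 128 ug/mL.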

Compound 4, half-maximal cytotoxic concentration: 16 ug/mL
Compound 4: the middle estimate sits 2.0-fold (0.30 log units) above what was measured, and the stated range covers the measured number.
By their numbers in this assay, from the lowest: compounds 4, 1, 3 and 2 (each within the scatter of the next, the first and the last beyond it).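

The thiosemicarbazone-type group entering on the double-bonded nitrogen gives an 8.0-fold lower number from compound 2 to compound 4 (0.90 log units; beyond the scatter), so a second replacement of the methoxy, quite unlike the first, also ends beyond the scatter from compound 2. The step of a 2.0-fold lower number from compound 1 to compound 4 (0.30 log units; within the scatter) shows that, in this assay, this larger group cannot be told apart from the single oxygen atom of compound 1, so among these compounds the clear separation lies between having the methoxy at this position and not having it, rather than between the two groups that replace it. Nothing measured here accounts for this difference.

On these data alone, whether the methoxy itself is what matters remains open, since an ethoxy group or a longer alkoxy chain on the same nitrogen could test this. A simple amine there would show whether any group without the methyl on oxygen falls in the same low range.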